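Compound 1 and the swap of phenyl for methoxy

The source may hold more compounds than are shown below. What is called first, only, known or untested is meant among the compounds shown, and "the series" means these compounds.

compound 1 `O=C(NCc1ccc(NC(=O)c2cc(-c3ccccc3)ccc2N2CCCC2)cc1)OCc1cccnc1`: 4340 nM
compound 2 `O=C(NCc1ccc(NC(=O)c2ccc(F)cc2N2CCCC2)cc1)OCc1cccnc1`: 1840 nM

In a functional assay on HGC-27 cells (Homo sapiens) for inhibition, read by MTT assay, with a stated time of 72 h (a higher number here means a weaker inhibitor, a lower number a stronger inhibitor), only these two compounds have been measured. Compound 1 stands at the top of this small set (4340 nM), and its gap to compound 2 lies beyond the usual scatter. For the measured compounds named here, nothing yet shows how compound 1 responds to a single change, because no pair of measured compounds differs in only one place.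

Compound 3 `COc1ccc(N2CCCC2)c(C(=O)Nc2ccc(CNC(=O)OCc3cccnc3)cc2)c1` keeps the core of compound 1 and makes one such change (methoxy in place of phenyl on an aromatic carbon): methoxy in place of phenyl on an aromatic carbon, para to a pyrrolidin-1-yl group. Going by the values given here, the only guide is compound 2, which also has no phenyl group and gives the lower number (1840 nM). That points to a modest move towards a lower number in this assay, one expected to stay within the scatter. The expected step is a 1.7-fold lower number from compound 1 to compound 3 (0.22 log units; within the scatter) and it remains an estimate. Compound 3 is expected at 2600 nM within an estimated range of 1000 nM to 6500 nM once it is measured.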

Compound 3, half-maximal inhibitory concentration: 138000 nM
The estimate for compound 3 lay 53-fold (1.72 log units) below the measured number; measured number outside the range, above it.
By their numbers in this assay, from the lowest: compound 2; then compound 1; then compound 3.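

For the compounds shown here, the swap of phenyl for methoxy is the first single change that can be read in this assay, and it is a large one: a 32-fold higher number from compound 1 to compound 3 (1.50 log units; beyond the scatter). It shows that this aromatic carbon, para to a pyrrolidin-1-yl group, is far from indifferent to what it carries, since on the core of compound 1 the exchange of phenyl for methoxy goes with a much weaker inhibitor. No measurement at hand gives a reason for this step, and this one pair cannot separate the departure of the aromatic ring from the arrival of the oxygen.

Going by these compounds, compound 2 differs from the other two compounds in more than one place, so its steps to them cannot be read, and the size of the effect on any other version of the core stays unknown. On these data alone, it remains open whether a methyl group, a chlorine atom, a cyclohexyl ring or a pyridine ring on this carbon would give a number close to that of compound 1 or close to that of compound 3.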